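Piperidin-4-yl for oxan-4-yl at the five-membered ring

A few compounds are considered here, and "the series" means these few. Any claim that something is new, unique, unknown or untested is made for them only; others in the source may bear on it.

Compound 1 `COc1cc(C(=O)N2CCCC2)ccc1-c1ccnc2[nH]c(C3CCOCC3)cc12` and compound 2 `Cc1nc2ccc(-c3ccnc4[nH]c(C5CCN(CC(=O)N(C)C)CC5)cc34)cc2n1C(C)C` share a core and have both been run through an ADME assay on cells (Hepatocyte, Homo sapiens) for metabolic stability; on this read-out lower numbers stand for slow clearance and higher numbers for fast clearance. In this assay compound 1 gives 46 uL/min, the higher of the two numbers; compound 2 gives 1.4 uL/min, a difference well beyond the usual scatter, though the two structures differ in several places at once and no single step can be read from them.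

Compound 3 `COc1cc(C(=O)N2CCCC2)ccc1-c1ccnc2[nH]c(C3CCNCC3)cc12` is the next compound to be measured. It differs from compound 1 in one place: piperidin-4-yl in place of oxan-4-yl on an aromatic carbon

For the measured compounds named here, with no single-point step on record, the expected direction rests on compound 2, whose substituent also contains a piperidine ring and which gives 1.4 uL/min in this assay. For compound 3 a downward step from compound 1 is therefore expected, a 3.1-fold lower number from compound 1 to compound 3 (0.49 log units; beyond the scatter), though smaller than the gap to compound 2. The estimate for compound 3 in this assay is 15 uL/min, with a range from 5 uL/min to 40 uL/min.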

Compound 3, intrinsic clearance in a liver preparation (reported as CLH), per the amount of preparation that the assay uses: < 1 uL/min
Compound 3 ended at the assay's limit (the forecaster's own chance of this, stated with the estimate: 5%); at least 15-fold (1.17 log units) between middle value and limit.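

In this assay, piperidin-4-yl in place of oxan-4-yl on an aromatic carbon of the five-membered ring gives an at least 46-fold lower number from compound 1 to compound 3 (1.66 log units; beyond the scatter). The value of compound 3, < 1 uL/min, is a limit of the assay and not a number: the limit of < 1 uL/min in this assay, at which 1 of the 3 values shown sits.

Compound 1 and compound 2 differ in several places, whereas this pair shows that the change at this one position, with the rest of compound 1 kept, is enough for a step beyond the scatter.

Still open, from the compounds shown here alone, is whether the step holds with a methyl or acetyl group on the piperidine nitrogen, or with an open-chain amine on the same carbon. Also open, going by these compounds, is whether the same exchange gives a step of similar size when the rest of the molecule differs from compound 1.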